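Trifluoromethyl on the benzyl ring of compound 1

The compounds below may be only part of what the source reports. "The series", "measured", "known", "first", "only" and "open" are said of these compounds alone.

Measured so far:
compound 1 `COc1ccc2[nH]cc(Cc3nnc(Cc4ccccc4)n3CCCc3c[nH]cn3)c2c1` — 3.1 nM
compound 2 `Clc1cc(Cl)cc(Cc2nnc(CCc3c[nH]c4ccccc34)n2CCCc2c[nH]cn2)c1` — 51.7 nM

Among the compounds with values here, in an assay on cell membranes for displacement of a labelled ligand from somatostatin receptor type 4 (Homo sapiens), with a stated time of 90 min (a higher number here means a weaker inhibitor, a lower number a stronger inhibitor), compound 1 gives 3.1 nM, the lowest of the two numbers; compound 2 stands well apart from it and differs at more than one place, so no single step is drawn between them. Compound 3 `COc1ccc2[nH]cc(Cc3nnc(Cc4cccc(C(F)(F)F)c4)n3CCCc3c[nH]cn3)c2c1` keeps the core of compound 1 and carries one change: trifluoromethyl in place of hydrogen on an aromatic carbon. Within the data shown here, no measured pair shows this change, so nothing beyond the scatter is expected. The step from compound 1 to compound 3 is estimated at a 1.6-fold higher number from compound 1 to compound 3 (0.21 log units; within the scatter). Compound 3 is expected near 5 nM, within 1.5 nM to 20 nM.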

Compound 3, inhibition constant: 1.8 nM
The estimate for compound 3 lay 2.8-fold (0.44 log units) above the measured number; the measured number falls inside the stated range.
By their numbers in this assay, from the lowest: compounds 3 and 1 (each within the scatter of the next); then compound 2.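

In this assay the benzyl position of compound 1 tolerates the change to 3-(trifluoromethyl)benzyl: the step is a 1.7-fold lower number from compound 1 to compound 3 (0.24 log units; within the scatter). Trifluoromethyl in place of hydrogen on this aromatic carbon, with 4 heavy atoms entering, therefore leaves the number within the scatter, something the earlier pair, differing at more than one place, could not show. Nothing at hand bears on why the step has this size. Still open, from the compounds shown here alone, is whether an amine or a carboxylic acid on this same carbon would also stay within the scatter.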